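Pyridinyl in Place of Trifluoromethylphenyl on a Shared Core

The source may hold more compounds than are shown below. What is called first, only, known or untested is meant among the compounds shown, and "the series" means these compounds.

Of the compounds shown here, two on a shared core have been measured. Among the compounds with values here, compound 1 `CC(C)(C)C(=O)N1Cc2c(NC(=O)c3ccncc3)n[nH]c2C1(C)C` and compound 2 `CN1CCC(C(=O)N2Cc3c(NC(=O)c4ccc(C(F)(F)F)cc4)n[nH]c3C2(C)C)CC1` differ from each other in more than one place, so no single step connects them. In a functional assay on A2780 cells (Homo sapiens) for antiproliferative activity, read by fluorescence, with a stated time of 72 h (a higher number here means a weaker inhibitor, a lower number a stronger inhibitor), compound 1 gives 110 nM. In this assay compound 2 gives 60 nM, the lower of the two numbers, but compound 1 lies within the scatter of it, so no order between them can be read. Compound 3 `CN1CCC(C(=O)N2Cc3c(NC(=O)c4ccncc4)n[nH]c3C2(C)C)CC1` differs from compound 2 in one place: pyridin-4-yl in place of 4-(trifluoromethyl)phenyl on a carbonyl carbon. Within the data shown here, no pair of measured compounds shows the size of this change on its own. Among the measured compounds shown here, compound 1, which also carries pyridin-4-yl on its carbonyl carbon, gives 110 nM, and that is the only guide. The step of a 1.5-fold higher number from compound 2 to compound 3 (0.18 log units; within the scatter) is expected to be small, toward a somewhat higher number, and within the scatter. Compound 3 is therefore expected at 90 nM, within a range of 40 nM to 200 nM.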

Compound 3, half-maximal inhibitory concentration: 500 nM
Compound 3: middle estimate off by 5.6-fold (0.74 log units), on the low side; measured number above the stated range.
By their numbers in this assay, from the lowest: compounds 2 and 1 (each within the scatter of the next); then compound 3.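

In this assay, the step from 4-(trifluoromethyl)phenyl to pyridin-4-yl on the carbonyl carbon gives an 8.3-fold higher number from compound 2 to compound 3 (0.92 log units; beyond the scatter), so with 1-methylpiperidin-4-yl held in place, this change lies beyond the scatter. The second step, 1-methylpiperidin-4-yl in place of tert-butyl on a carbonyl carbon, gives a 4.5-fold higher number from compound 1 to compound 3 (0.66 log units; beyond the scatter), which shows that with pyridin-4-yl held in place, the number also depends on this other group. No measurement shown here accounts for the size or direction of either step.

The compounds shown leave open whether the step from compound 2 to compound 3 follows the loss of the trifluoromethyl group or the entry of the ring nitrogen, which an unsubstituted phenyl ring on the same carbonyl carbon could separate. They also leave open how tert-butyl behaves alongside 4-(trifluoromethyl)phenyl.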